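Aryl change on the ring nitrogen: compound 3 to compound 4

A few compounds are considered here, and "the series" means these few. Any claim that something is new, unique, unknown or untested is made for them only; others in the source may bear on it.

Compound 1 `Cc1ccccc1-n1cc(-c2ccc(NS(=O)(=O)c3c[nH]c(=O)[nH]c3=O)cc2)nn1` in a functional assay on HepG2 cells (Homo sapiens) for antiproliferative activity, read by MTT assay, with a stated time of 24 h (a lower number here means a stronger inhibitor, a higher number a weaker inhibitor), gives 14500 nM. Compound 2 `Cc1cccc(-n2cc(-c3ccc(NS(=O)(=O)c4c[nH]c(=O)[nH]c4=O)cc3)nn2)c1` in this assay gives only a limit, > 20000 nM. Compound 3 `O=c1[nH]cc(S(=O)(=O)Nc2ccc(-c3cn(-c4cccc(F)c4)nn3)cc2)c(=O)[nH]1` likewise stands at a limit in this assay, giving > 20000 nM, so its place on the numbers is a bound rather than a point. Two of the three values shown sit at the limit of > 20000 nM in this assay, at which 2 of the 3 values shown sit. The recorded steps are an at least 1.3-fold higher number from compound 1 to compound 2 (0.13 log units; that floor lies within the scatter), an at least 1.3-fold higher number from compound 1 to compound 3 (0.13 log units; that floor lies within the scatter) and a step that the two limits leave unreadable from compound 2 to compound 3. Compound 4 `O=c1[nH]cc(S(=O)(=O)Nc2ccc(-c3cn(-c4ccccc4Cl)nn3)cc2)c(=O)[nH]1` carries the change (2-chlorophenyl in place of 3-fluorophenyl on an aromatic nitrogen). The steps from compound 1 bear on it insofar as each variation of the aryl group on the ring nitrogen has so far ended at or beyond the limit in this assay; the step from compound 2 to compound 3 is not readable. Among the measured compounds shown here, nothing among the measured steps points to a gain beyond the scatter, and a return toward the value of compound 1, 14500 nM, is the most that can be read in. Compound 4 is therefore expected near 20000 nM, with a range from 8000 nM to 60000 nM. The expected step from the limit is a number no higher from compound 3 to compound 4 (the limit leaves the size open).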

Compound 4, half-maximal inhibitory concentration: 2230 nM
For compound 4 the middle estimate is 9.0-fold (0.95 log units) above the measured one; the whole stated range lies above it.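

In this assay, among the compounds shown here, 2-chlorophenyl on the aromatic nitrogen gives the first step that is clearly beyond the scatter towards a lower number, an at least 8.9-fold lower number from compound 3 to compound 4 (0.95 log units; beyond the scatter), and it also gives an at least 8.9-fold lower number from compound 2 to compound 4 (0.95 log units; beyond the scatter). Compound 1 and compound 4 differ only in that 2-chlorophenyl stands where compound 1 has 2-methylphenyl, and that single change gives a 6.5-fold lower number from compound 1 to compound 4 (0.81 log units; beyond the scatter), so the series responds to the group on this aryl ring even when the place of substitution stays the same. Compound 2 and compound 3 both stand at a limit, so the steps from them are floors and the step between them cannot be read: the limit of > 20000 nM in this assay, at which 2 of the 4 values shown sit.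

Going by these compounds, it remains open whether 2-fluorophenyl would track compound 4 or whether 3-chlorophenyl would stay at the limit, which would separate the effect of chloro from that of its place on the ring. Also open, on these data alone, is how a 2-methoxyphenyl group, or an aryl group carrying an amine or a carboxylic acid, would behave here.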